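Cytotoxicity notes on an amide series, toward compound 4

The compounds below may be only part of what the source reports. "The series", "measured", "known", "first", "only" and "open" are said of these compounds alone.

Measured compounds:
Compound 1 `COc1ccc2nc(NC(=O)c3ccc(F)cc3)n(C)c2c1` gives > 100000 nM in a toxicity assay on THP-1 cells (Homo sapiens) for inhibition (a lower number here means that less compound is tolerated, a higher number that more compound is tolerated), a limit of the assay.
Compound 2 `COc1ccc(-c2cnc(NC(=O)c3ccccc3OC)n2C)cc1` gives > 100000 nM in this assay, also a limit of the assay.
Compound 3 `Cc1ccc(C(=O)Nc2ncc(-c3ccccc3)o2)cc1` gives 26000 nM in this assay.

Compound 2 thus stands at the limit of > 100000 nM in this assay, at which 2 of the 3 values shown sit, with no number of its own; compound 3 alone returns a number. The change to compound 4 `COc1ccc(-c2cnc(NC(=O)c3cccc(Br)c3)n2C)cc1` is 3-bromophenyl in place of 2-methoxyphenyl on a carbonyl carbon. For the measured compounds named here, no measured pair differs in one place, so the expectation rests only on the two limits and the single number. For compound 4 a value near 80000 nM is expected, within 25000 nM to 200000 nM, and a limit rather than a number is the likelier outcome. The expected step of an at least 1.2-fold lower number from compound 2 to compound 4 (0.09 log units; that floor lies within the scatter) is therefore none beyond the scatter.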

Compound 4, half-maximal cytotoxic concentration: > 100000 nM
Compound 4: no number, only a limit; the forecaster's own chance of this, stated with the estimate: 60%; at least 1.2-fold (0.09 log units) between middle value and limit.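

Compound 2 and compound 4 both stand at a limit of this assay, so no step can be read between them. Still open, going by these compounds, is whether 3-bromophenyl in place of 2-methoxyphenyl changes the tolerated concentration at all.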